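Pyrazoline sulfonamides: trimethoxyphenyl replacing styryl on the ring carbon

This account rests on a few compounds, and the source may have more. Where it says the series, first, only, none or still open, it means among the compounds named here.

Compound 1 `Cc1cc(O)c(C2=NN(c3ccc(S(N)(=O)=O)cc3)C(c3ccccc3Cl)C2)cc1Cl` gives 3260 nM in a functional assay on K562 cells (Homo sapiens) for antiproliferative activity, with a stated time of 48 h; a higher number here means a weaker inhibitor of growth, a lower number a stronger inhibitor of growth. Going by the values given here, compound 2 `Cc1cc(O)c(C2=NN(c3ccc(S(N)(=O)=O)cc3)C(/C=C/c3ccccc3)C2)cc1Cl` gives 11600 nM in this assay, the higher of the two numbers so far; its nearest neighbour is compound 1, and the step of a 3.6-fold higher number from compound 1 to compound 2 (0.55 log units; beyond the scatter) separates them. Compound 3 `COc1ccc(C2CC(c3cc(Cl)c(C)cc3O)=NN2c2ccc(S(N)(=O)=O)cc2)c(OC)c1OC` is not yet measured. It differs from compound 2 by 2,3,4-trimethoxyphenyl in place of 2-phenylethenyl on a saturated ring carbon. Among the compounds with values here, the only measured step that bears on this position is a 3.6-fold higher number from compound 1 to compound 2 (0.55 log units; beyond the scatter), in which an aryl group gave way to the 2-phenylethenyl chain at the same saturated ring carbon and the number rose. Compound 3 restores an aryl group there, though not the same one as in compound 1, so the change is expected to move the number back down by a modest amount rather than to leave it unchanged. Compound 3 is therefore expected to give about 3500 nM in this assay, between 1000 nM and 12000 nM, an expected step of a 3.3-fold lower number from compound 2 to compound 3 (0.52 log units; beyond the scatter).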

Compound 3, concentration for 50% growth inhibition: 3220 nM
Compound 3: the middle estimate sits 1.1-fold (0.04 log units) above what was measured; the measured number falls inside the stated range.
By their numbers in this assay, from the lowest: compounds 3 and 1 (each within the scatter of the next); then compound 2.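

In this assay, the step of a 3.6-fold lower number from compound 2 to compound 3 (0.56 log units; beyond the scatter) shows that a second aryl group, 2,3,4-trimethoxyphenyl, also gives a lower number than 2-phenylethenyl on this saturated ring carbon, so this is not confined to 2-chlorophenyl. The step of a 1.0-fold lower number from compound 1 to compound 3 (0.01 log units; within the scatter) adds that these two aryl groups cannot be told apart here, even though their substituents are quite different. Nothing available gives a reason for these numbers.

Still open, as far as these compounds go, is whether any aryl group at this carbon gives a similar number, or only these two. An unsubstituted phenyl, a pyridine ring, a saturated butyl chain or a group bearing a carboxylic acid or an amine could separate those readings.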